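This account rests on a few compounds, and the source may have more. Where it says the series, first, only, none or still open, it means among the compounds named here.

Three related compounds have been tested in a functional assay on SMMC-7721 cells (Homo sapiens) for cytotoxicity, read by MTT assay, with a stated time of 24 h; a lower number here means a stronger inhibitor, a higher number a weaker inhibitor: compound 1 (`CN1C/C(=C\c2cccnc2)C(=O)/C(=C/c2cc([N+](=O)[O-])ccc2F)C1`), compound 2 (`O=C1/C(=C/c2cccnc2)CN(S(=O)(=O)c2ccccc2)C/C1=C\c1ccccc1F`) and compound 3 (`O=C1/C(=C/c2cccnc2)CN(S(=O)(=O)c2ccccc2)C/C1=C\c1ccccc1C(F)(F)F`). In this test compound 1 gives 6170 nM and compound 2 gives 19100 nM. Compound 3 gives 10900 nM, a number within the usual scatter of both of the others, so the data do not separate it from either one.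

Compound 4 (`O=C1/C(=C/c2cccnc2)CN(S(=O)(=O)c2ccc(Br)cc2)C/C1=C\c1ccccc1C(F)(F)F`) has not yet been measured. It differs from compound 3 in a single place: bromo in place of hydrogen on an aromatic carbon. This is bromo in place of hydrogen on an aromatic carbon, para to a large group, which turns phenylsulfonyl into (4-bromophenyl)sulfonyl.

Among the measured compounds shown here, only one measured step changes a single place: trifluoromethyl in place of fluoro on an aromatic carbon gives a 1.8-fold lower number from compound 2 to compound 3 (0.24 log units; within the scatter). That step involves neither bromo nor the phenylsulfonyl group, so it is only loose guidance, and no measurement shows what adding bromo does here. Compound 3, at 10900 nM, is therefore the natural starting point, and no step beyond the scatter is expected in this assay. The expected move is a 1.2-fold lower number from compound 3 to compound 4 (0.08 log units; within the scatter). For compound 4 the estimated value is 9000 nM, with an expected range from 3500 nM to 22000 nM.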

Compound 4, half-maximal inhibitory concentration: 5760 nM
For compound 4 the middle estimate is 1.6-fold (0.19 log units) above the measured one; measured number inside the range.
By their numbers in this assay, from the lowest: compounds 4, 1, 3 and 2 (each within the scatter of the next, the first and the last beyond it).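

Bromo in place of hydrogen on an aromatic carbon of the phenylsulfonyl group gives a 1.9-fold lower number from compound 3 to compound 4 (0.28 log units; within the scatter) in this assay, so the data do not separate compound 4 from compound 3. Among the compounds shown here, this is the first measured change on that ring rather than on the ring bearing fluoro or trifluoromethyl, and it shows that a bromo para to a large group, turning phenylsulfonyl into (4-bromophenyl)sulfonyl, brings no loss beyond the scatter in this cytotoxicity read-out, although it does not establish a gain either. No measurement is available that bears on how this result comes about.

The compounds shown leave open how a chloro, a methoxy or an amine on the same aromatic carbon would compare with bromo, and so whether any group at this place can move the number beyond the scatter. They also leave open whether bromo gives a similar step when the other ring carries the fluoro of compound 2 instead of the trifluoromethyl of compound 3.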